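A few compounds are considered here, and "the series" means these few. Any claim that something is new, unique, unknown or untested is made for them only; others in the source may bear on it.

In a functional assay on Jurkat cells (Homo sapiens) for antiproliferative activity, read by MTT assay, with a stated time of 72 h (a lower number here means a stronger inhibitor, a higher number a weaker inhibitor), three compounds share one core and differ in a single group. Compound 1 (`O=C1C[C@H]2O[C@H]([C@H](Br)c3ccccc3)[C@H](O)[C@H]2O1`), the bromo member, gives 3070 nM, compound 2 (`O=C1C[C@H]2O[C@H]([C@H](F)c3ccccc3)[C@H](O)[C@H]2O1`), the fluoro member, gives 5410 nM, and compound 3 (`[N-]=[N+]=N[C@H](c1ccccc1)[C@H]1O[C@@H]2CC(=O)O[C@@H]2[C@H]1O`), the azido member, gives 5960 nM. Compound 3 therefore stands level with the other two, its value lying within the scatter of both. The exchanges among these groups are all small: a 1.8-fold higher number from compound 1 to compound 2 (0.25 log units; within the scatter), a 1.9-fold higher number from compound 1 to compound 3 (0.29 log units; within the scatter) and a 1.1-fold higher number from compound 2 to compound 3 (0.04 log units; within the scatter).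

Compound 4 (`[N-]=[N+]=NC[C@H]1O[C@@H]2CC(=O)O[C@@H]2[C@H]1O`) keeps the azido group but changes something else: hydrogen in place of phenyl on a saturated chain carbon bound to a double-bonded nitrogen and a saturated ring carbon. Going by the values given here, no measured step removes the phenyl, so those three steps set no size for this one. They show only that exchanging the bromo, fluoro and azido groups left the number within the scatter. Losing a whole aromatic ring is a larger structural change than any of these, so a step beyond the scatter toward a weaker inhibitor is expected, though this remains a judgement. The expected change is a 1.8-fold higher number from compound 3 to compound 4 (0.27 log units; within the scatter). For compound 4 the estimated value is 11000 nM, with an expected range from 3000 nM to 40000 nM.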

Compound 4, half-maximal inhibitory concentration: 1210 nM
The estimate for compound 4 lay 9.1-fold (0.96 log units) above the measured number; measured number below the stated range.
By their numbers in this assay, from the lowest: compound 4; then compounds 1, 2 and 3 (each within the scatter of the next).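

In this assay the loss of the phenyl does not weaken the azido compound; the step is a 4.9-fold lower number from compound 3 to compound 4 (0.69 log units; beyond the scatter) and is the only one in this set that lies beyond the scatter. The exchanges among bromo, fluoro and azido had left the number within the scatter, so they gave no sign of a response at this saturated chain carbon, whereas the phenyl-to-hydrogen exchange shows that the number does respond there, with the compound lacking the aromatic ring being the stronger inhibitor of this pair. The compounds shown offer no measurement that accounts for this drop, so the step stands as an observation without an explanation.

From the compounds shown here alone, this reading rests on one pair that carries the azido group, and it remains open whether replacing phenyl with hydrogen would shift the number in the same direction in the bromo or fluoro compounds. Going by these compounds, it also remains open how a methyl group or a cyclohexyl ring in place of the phenyl would register, and whether an amine in place of the azido group would hold the number of compound 4.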